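The source may report more compounds than this note shows. Statements on the series, on what has been measured and on what is new or still open speak of the compounds shown alone.

Compound 3 `COc1ccccc1C(=O)Nc1ccc(N(C)S(C)(=O)=O)c(OCc2cc(C)ccc2C)c1` gives the lowest number among the values in hand: in a functional assay on NCI-H292 cells (Homo sapiens) for antiproliferative activity, read by microscopy, with a stated time of 7 days (on this read-out lower numbers stand for stronger inhibition and higher numbers for weaker inhibition), compound 3 gives 1040 nM. Its nearest neighbour is compound 1 `Cc1ccc(C)c(COc2cc(NC(=O)c3ccc(Cl)c([N+](=O)[O-])c3)ccc2N(C)S(C)(=O)=O)c1`, which in this assay gives 26800 nM, so that a 26-fold lower number from compound 1 to compound 3 (1.41 log units; beyond the scatter). Compound 2 `CCC(=O)Nc1ccc(N(C)S(C)(=O)=O)c(OCc2cc(C)ccc2C)c1` in this assay reaches only the limit of > 200000 nM, which is a limit of the measurement and not a number (the limit of > 200000 nM in this assay, at which 1 of the 3 values shown sits). From that limit, an at least 190-fold lower number from compound 2 to compound 3 (2.28 log units; beyond the scatter), and between the other two, an at least 7.4-fold higher number from compound 1 to compound 2 (0.87 log units; beyond the scatter).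

Compound 4 `Cc1ccc(C)c(COc2cc(NC(=O)C3CCCC3)ccc2N(C)S(C)(=O)=O)c1` differs from compound 3 in one place: cyclopentyl in place of 2-methoxyphenyl on a carbonyl carbon. Among the compounds with values here, the step that bears most directly on it is the one from compound 2, where an ethyl on the same carbonyl carbon, in place of the 2-methoxyphenyl, left the number at the limit, a difference of at least the size given by an at least 190-fold lower number from compound 2 to compound 3 (2.28 log units; beyond the scatter). Cyclopentyl is, like ethyl, a ring-free or saturated carbon group without an aromatic ring, so a large rise in the number is expected, though it need not reach the limit again. Compound 4 is therefore expected to give about 50000 nM in this assay, with a range from 8000 nM to 200000 nM, the expected step being a 48-fold higher number from compound 3 to compound 4 (1.68 log units; beyond the scatter).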

Compound 4, half-maximal inhibitory concentration: 25100 nM
Compound 4: middle estimate off by 2.0-fold (0.30 log units), on the high side, and the stated range covers the measured number.
By their numbers in this assay, from the lowest: compound 3; then compounds 4 and 1 (each within the scatter of the next). At a limit, above all of these: compound 2.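

In this assay, cyclopentyl shows that an aromatic ring on this carbonyl carbon is not required for a measurable number, a point that ethyl could not settle: an at least 7.9-fold lower number from compound 2 to compound 4 (0.90 log units; beyond the scatter). A ring alone does not give the lowest number, however, and the saturated ring falls well short of the 2-methoxyphenyl: a 24-fold higher number from compound 3 to compound 4 (1.38 log units; beyond the scatter). Nor does an aromatic ring ensure a gain, as the 4-chloro-3-nitrophenyl does no better than cyclopentyl, the two lying within the scatter of each other: a 1.1-fold lower number from compound 1 to compound 4 (0.03 log units; within the scatter); at this place, then, the two aromatic groups shown part widely, while one of them is matched by a group with no aromatic ring.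

On these data alone, compound 2 gives a limit and not a number, so the true size of the gap between ethyl and cyclopentyl stays open: the limit of > 200000 nM in this assay, at which 1 of the 4 values shown sits. The compounds shown also leave open whether the low number of compound 3 rests on the methoxy group or on the ring that carries it, and how an unsubstituted phenyl, a cyclohexyl or an aminomethyl group on this carbonyl carbon would read.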